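The source may report more compounds than this note shows. Statements on the series, on what has been measured and on what is new or still open speak of the compounds shown alone.

Measured so far in a functional assay on MGC-803 cells (Homo sapiens) for antiproliferative activity, read by MTT assay; on this read-out lower numbers stand for stronger inhibition and higher numbers for weaker inhibition:
compound 1 `Cc1ccc(NC(=O)Nc2cccc(CNc3ncnc4ccccc34)c2)cc1`: 31200 nM
compound 2 `CC(C)(C)c1ccc(NC(=O)Nc2cccc(CNc3ncnc4ccccc34)c2)cc1`: 7470 nM
compound 3 `COc1cc2ncnc(NCc3cccc(NC(=O)Nc4cccc(C)c4)c3)c2cc1OC`: 44600 nM

Compound 3 gives the highest of the three numbers in this assay; its gap to compound 1 is within the scatter, while compound 2 sits clearly apart. Going by the values given here, the single measured step, a 4.2-fold lower number from compound 1 to compound 2 (0.62 log units; beyond the scatter), concerns a change on the same outer ring. Compound 4 `COc1cc2ncnc(NCc3cccc(NC(=O)Nc4ccc(Cl)cc4)c3)c2cc1OC` differs from compound 3 by 4-chlorophenyl in place of 3-methylphenyl on an amide-type nitrogen. Among the compounds with values here, no measured step covers this exchange directly; the one step that is known moved the number beyond the scatter, so a shift in the same direction, of smaller size, is expected here, with little confidence. Compound 4 is expected near 20000 nM, in the range 6000 nM to 60000 nM. The expected step is a 2.2-fold lower number from compound 3 to compound 4 (0.35 log units; beyond the scatter).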

Compound 4, half-maximal inhibitory concentration: 44200 nM
For compound 4 the middle estimate is 2.2-fold (0.34 log units) below the measured one; low and high end bracket the measured number.
By their numbers in this assay, from the lowest: compound 2; then compounds 1, 4 and 3 (each within the scatter of the next).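

On the amide-type nitrogen, 4-chlorophenyl in place of 3-methylphenyl gives a 1.0-fold lower number from compound 3 to compound 4 (0.00 log units; within the scatter) in this assay and so leaves the two compounds indistinguishable. In this series, on the core of compound 3, the identity of the substituent on the outer ring and its printed ring position can change together without a readable shift. No available evidence bears on this result. Still open, as far as these compounds go, is whether the tert-butyl group of compound 2 would give a lower number on the core of compound 3. Also open, from the compounds shown here alone, is whether an amine or a carboxylic acid on the outer ring would shift the number.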